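Glucagon receptor binders: a chloro to trifluoromethylsulfanyl swap

This account rests on a few compounds, and the source may have more. Where it says the series, first, only, none or still open, it means among the compounds named here.

Measured compounds:
compound 1, `O=C(O)CCNC(=O)c1ccc(CN(c2ccc(Cl)cc2)c2nc(-c3ccc(C(F)(F)F)cc3)cs2)cc1`, 76 nM
compound 2, `O=C(O)CCNC(=O)c1ccc(CN(c2ccc3c(c2)CCCC3)c2nc(-c3ccc(Cl)c(Cl)c3)cs2)cc1`, 79 nM

Of the compounds shown here, two sharing the same core have been measured in an in vitro assay on BHK cells for displacement of a labelled ligand from Glucagon receptor (Homo sapiens), read by scintillation proximity assay; on this read-out higher numbers stand for weaker inhibition and lower numbers for stronger inhibition. Compound 1 gives 76 nM, and compound 2 gives 79 nM. Compound 1 carries the lowest of the two numbers, but the gap to compound 2 lies within the usual scatter of such measurements, so the two values show no difference that can be read as order.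

The next compound, compound 3, is `O=C(O)CCNC(=O)c1ccc(CN(c2ccc(SC(F)(F)F)cc2)c2nc(-c3ccc(C(F)(F)F)cc3)cs2)cc1`. It differs from compound 1 in one place: (trifluoromethyl)sulfanyl in place of chloro on an aromatic carbon. Going by the values given here, no measured pair shows the effect of this exchange, so its size is open. With only the two values above to go on, the step from compound 1 to compound 3 in this assay is expected to be small, at most a modest move toward a lower number, and quite possibly nothing beyond the scatter; the expected step is a 1.3-fold lower number from compound 1 to compound 3 (0.10 log units; within the scatter). Compound 3 is therefore estimated at 60 nM, with the likely range running from 25 nM to 150 nM.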

Compound 3, half-maximal inhibitory concentration: 34 nM
For compound 3 the middle estimate is 1.8-fold (0.25 log units) above the measured one; the measured number falls inside the stated range.
By their numbers in this assay, from the lowest: compound 3; then compounds 1 and 2 (each within the scatter of the next).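

In this assay, (trifluoromethyl)sulfanyl in place of chloro on an aromatic carbon, para to a large group, gives a 2.2-fold lower number from compound 1 to compound 3 (0.35 log units; beyond the scatter). This is the first exchange in one place among these compounds, so it gives the first direct reading of this position: the two earlier values came from compounds that differ in more than one place and could not isolate it. Here, a group of 5 heavy atoms replaces a single chlorine with a modest move toward stronger inhibition rather than a loss, but nothing measured for these compounds accounts for the size or direction of the step.

The compounds shown do not separate the part played by the sulfur from that of the trifluoromethyl, so a methylsulfanyl group, a trifluoromethoxy group or a trifluoromethyl group on the same carbon would each be needed to tell these apart. From the compounds shown here alone, whether the same exchange moves the number on the core of compound 2 also remains open, as does how a single result at this position extends to any other group there.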